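A few compounds are considered here, and "the series" means these few. Any claim that something is new, unique, unknown or untested is made for them only; others in the source may bear on it.

Measured so far in a functional assay on A549 cells (Homo sapiens) for antiproliferative activity, read by MTT assay, with a stated time of 48 h; on this read-out lower numbers stand for stronger inhibition and higher numbers for weaker inhibition:
- compound 1 `Cc1ccc(Nc2ccc3c(c2)/C(=C\C2CCCCC2)C(=O)N3)cc1`: 28200 nM
- compound 2 `CC(C)C/C=C1/C(=O)Nc2ccc(Nc3ccc(Cl)cc3)cc21`: 7400 nM
- compound 3 `Cc1ccc(Nc2ccc3c(c2)C(CC2CCCCC2)C(=O)N3)cc1`: > 30000 nM

Compound 3 has no number, only a limit of the assay: the limit of > 30000 nM in this assay, at which 1 of the 3 values shown sits.

Compound 4 `O=C1Nc2ccc(Nc3ccc(Cl)cc3)cc2C1CC1CCCCC1` comes from compound 3 by a single change, chloro in place of methyl on an aromatic carbon, para to a large group: chloro in place of methyl on an aromatic carbon. Going by the values given here, no pair of measured compounds shows this change on its own. Compound 1, which carries 4-methylphenyl, gives 28200 nM. Compound 2, which carries 4-chlorophenyl, gives 7400 nM, the lower number of the two. These two values offer only a loose hint for the change at hand.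

On that hint, a modest step toward stronger inhibition is expected in this assay, and a second limit reading for compound 4 would not be surprising. The estimated step is an at least 1.8-fold lower number from compound 3 to compound 4 (0.27 log units; that floor lies within the scatter). For compound 4 the estimated value is 16000 nM, with an expected range from 6000 nM to 30000 nM.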

Compound 4, half-maximal inhibitory concentration: 16600 nM
For compound 4 the middle estimate is 1.0-fold (0.02 log units) below the measured one; the measured number falls inside the stated range.
By their numbers in this assay, from the lowest: compound 2; then compounds 4 and 1 (each within the scatter of the next). At a limit, above all of these: compound 3.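

Chloro in place of methyl on an aromatic carbon, para to a large group, now has its first direct reading in this assay, within a single pair of cyclohexylmethyl compounds: an at least 1.8-fold lower number from compound 3 to compound 4 (0.25 log units; that floor lies within the scatter). Compound 4 gives 16600 nM, so a number within the range of the assay is reached with 4-chlorophenyl on this side chain, and the earlier hint from two compounds that differ in more than one place is replaced by a matched comparison. The reading for compound 3 is a limit and not a number, so the step is only a floor and its true size remains unknown: the limit of > 30000 nM in this assay, at which 1 of the 4 values shown sits.

Open, on these data alone, is whether the same change carries over to the compounds with the double bond, as compound 1 and compound 2 differ in more than this one place and do not settle the matter. Also open, as far as these compounds go, is how the number responds to other groups on this aromatic carbon, such as fluoro, methoxy or a carboxylic acid, so the reading for chloro and methyl cannot yet be placed in a wider trend.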